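The source may hold more compounds than are shown below. What is called first, only, known or untested is meant among the compounds shown, and "the series" means these compounds.

Working notes on the series. Compound 2 `Cc1ccccc1-n1nc(C)c2c1NC(=O)[C@H](C)S[C@@H]2c1ccc(-c2cc3ccccc3o2)cc1` gives 17% in an assay on isolated protein for agonist activity at Bile acid receptor (Homo sapiens), read by AlphaScreen, with a stated time of 30 min (a lower number here means a smaller maximal response, a higher number a larger maximal response), the lowest of the three numbers; compound 3 `Cc1cccc(-n2nc(C)c3c2NC(=O)[C@H](C)S[C@@H]3c2ccc(Oc3ccccc3)cc2)c1` gives 22%, within the scatter of compound 2, while compound 1 `CCc1ccccc1-n1nc(C)c2c1NC(=O)[C@H](C)S[C@@H]2c1ccc(Oc2ccccc2)cc1` gives 190%, far above. Within the data shown here, the only single-point step measured is a number 168 percentage points lower from compound 1 to compound 3 (beyond the scatter), and it concerns the group on the aromatic nitrogen, not the group changed here. Compound 4 `COc1cccc(Oc2ccc([C@H]3S[C@@H](C)C(=O)Nc4c3c(C)nn4-c3ccccc3C)cc2)c1` differs from compound 2 by 3-methoxyphenoxy in place of 1-benzofuran-2-yl on an aromatic carbon. Among the measured compounds shown here, no measured pair isolates this change, so the expectation rests on the spread of the three values. For compound 4 the expected step is a number 23 percentage points higher from compound 2 to compound 4 (beyond the scatter). The estimate for compound 4 in this assay is 40%, within 10% to 160%.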

Compound 4, largest response reached (reported as efficacy), in percent of the reference or control that the assay uses: 120%
Compound 4: middle estimate off by 80 percentage points, on the low side; low and high end bracket the measured number.
By their numbers in this assay, from the lowest: compounds 2 and 3 (each within the scatter of the next); then compound 4; then compound 1.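

With the 2-methylphenyl group on the aromatic nitrogen held constant, the group on the aromatic carbon para to a large group strongly sets the maximal response in this assay: the exchange of 1-benzofuran-2-yl for 3-methoxyphenoxy gives a number 103 percentage points higher from compound 2 to compound 4 (beyond the scatter). The maximal response therefore depends on this position as well as on the group on the aromatic nitrogen. Nothing available here explains the size of this step. Open, from the compounds shown here alone, is how much of the step belongs to the methoxy group rather than the phenoxy group. Also open, going by these compounds, is how an amine or a carboxylic acid in place of that methoxy would read in this assay.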